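A few compounds are considered here, and "the series" means these few. Any claim that something is new, unique, unknown or untested is made for them only; others in the source may bear on it.

Three compounds with a shared core have been examined in a functional assay on HepG2 cells (Homo sapiens) for cytotoxicity, read by MTT assay, with a stated time of 48 h; a lower number here means a stronger inhibitor, a higher number a weaker inhibitor. Compound 1 `O=Cc1c(O)ccc2oc(-c3cccc4ccccc34)nc12` carries a bulky aromatic group on one side of the core and an aldehyde on the other; in this assay compound 1 gives 27700 nM. Compound 2 `O=Cc1c(O)ccc2oc(-c3cccc(Cl)c3)nc12` keeps the aldehyde and has a smaller chlorine-bearing ring instead; compound 2 gives 810 nM. Compound 3 `CC(=O)c1c(O)ccc2oc(-c3ccccc3)nc12` replaces the aldehyde with an acetyl group and carries a plain phenyl ring. For compound 3 the assay returned only a limit, > 30000 nM, not a number, which is the boundary described by the limit of > 30000 nM in this assay, at which 1 of the 3 values shown sits. Compound 3 therefore stands at the weak end of the values seen so far, with no exact figure to place it more finely.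

Compound 4 `CC(=O)c1c(O)ccc2oc(-c3ccccc3C)nc12` differs from compound 3 in one place: methyl in place of hydrogen on an aromatic carbon. No change of this kind has been measured among the three compounds, so there is nothing to set its size from. A methyl group is a small addition, and the expected step from compound 3 to compound 4 is a step that the limit leaves unreadable from compound 3 to compound 4, that is, no change beyond the usual scatter. Compound 4 is accordingly estimated at 40000 nM, within a range of 15000 nM to 150000 nM, with a fair chance that the assay again reports only a limit.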

Compound 4, half-maximal inhibitory concentration: 11700 nM
Compound 4: middle estimate off by 3.4-fold (0.53 log units), on the high side; measured number outside the range, below it.
By their numbers in this assay, from the lowest: compound 2; then compound 4; then compound 1. At a limit, above all of these: compound 3.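

In this assay, methyl in place of hydrogen on an aromatic carbon, ortho to a large group, brings an at least 2.5-fold lower number from compound 3 to compound 4 (0.40 log units; beyond the scatter). Among these compounds, this is the first single change that can be read in this set, and it shows that this place on the ring is not indifferent: one heavy atom is enough to move the compound from a limit to a measured number, with the acetyl group and the rest of the shared core unchanged. The step gives only a lower bound on the size of the change, and the real gap may be wider, because compound 3 has only a limit as its value: the limit of > 30000 nM in this assay, at which 1 of the 4 values shown sits.

On these data alone, it remains open whether the shift belongs to methyl in particular or would also follow from another group at this place, such as ethyl, a methoxy group or an amine, and whether methyl on a different carbon of the same ring would do the same. As far as these compounds go, it is equally open whether the step would carry over to a compound with an aldehyde in place of the acetyl group.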